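The compounds below may be only part of what the source reports. "The series", "measured", "known", "first", "only" and "open" are said of these compounds alone.

Measured in an ADME assay on L6 cells (Rattus norvegicus) for inhibition, read by fluorescence, with a stated time of 72 h; a lower number here means a stronger inhibitor, a higher number a weaker inhibitor:
- Compound 1 `Cc1cc(=O)oc2cc(Oc3ccc(Cl)cc3O)ccc12`: 85900 nM
- Compound 2 `O=c1oc2cc(O)ccc2cc1Oc1ccc(Cl)cc1O`: 144000 nM
- Compound 3 `O=c1oc2cc(O)cc(O)c2cc1Oc1ccc(Cl)cc1O`: 128000 nM

Compound 2, at 144000 nM, has the highest number of the three, but its gaps to the other two lie within the usual scatter, so the series shows no real order. Compound 4 `Cc1c(Oc2ccc(Cl)cc2O)c(=O)oc2cc(O)ccc12` differs from compound 2 by methyl in place of hydrogen on an aromatic carbon. For the measured compounds named here, no measured step makes this exact change. The only one available, a 1.1-fold lower number from compound 2 to compound 3 (0.05 log units; within the scatter), places a hydroxy rather than a methyl on an aromatic carbon, and it shows no change beyond the scatter. A methyl group also appears in compound 1, at 85900 nM, but that compound differs from compound 4 in more than one place, so it offers no clean comparison. As far as these compounds go, on this evidence, no step beyond the scatter is expected in this assay, and the direction stays open. The expected step is a 1.2-fold lower number from compound 2 to compound 4 (0.08 log units; within the scatter). Compound 4 is estimated at 120000 nM, with an expected range of 60000 nM to 220000 nM.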

Compound 4, half-maximal inhibitory concentration: 96300 nM
Estimate against measurement, compound 4: 1.2-fold (0.10 log units) above; the measured number falls inside the stated range.
By their numbers in this assay, from the lowest: compounds 1, 4, 3 and 2 (each within the scatter of the next).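

In this assay, for the compounds shown here, this is the first direct reading of a methyl on the aromatic carbon opposite the ring oxygen (a 1.5-fold lower number from compound 2 to compound 4 (0.17 log units; within the scatter)). Going by these compounds alone, the only earlier step concerned a hydroxy group, so it is this result that shows a methyl in place of hydrogen at this position also leaves the number within the scatter. No evidence on any property of these compounds bears on this result, and it offers no explanation for it.

The compounds shown leave open whether a longer chain, an amine or a carboxylic acid on this same aromatic carbon would take the number beyond the scatter. They also cannot tell whether any group at this position would give a step that can be read in either direction.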